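Amine variation on the amide side of the series

This account rests on a few compounds, and the source may have more. Where it says the series, first, only, none or still open, it means among the compounds named here.

Among the measured compounds shown here, compound 2 `CN(C)CCNC(=O)CCC(=O)OCCCCCCSc1ccc([N+](=O)[O-])c2nonc12` is the stronger of the two compounds measured so far in an assay on isolated protein for inhibition of glutathione S-transferase P (Homo sapiens), with a stated time of 10 min; on this read-out lower numbers stand for stronger inhibition and higher numbers for weaker inhibition: compound 2 gives 540 nM, whereas compound 1 `O=C(CCC(=O)OCCCCCCSc1ccc([N+](=O)[O-])c2nonc12)Nc1ccc(Br)cc1` gives 5090 nM. For the measured compounds named here, the only step recorded between measured compounds, a 9.4-fold lower number from compound 1 to compound 2 (0.97 log units; beyond the scatter), concerns the exchange of an aryl group for an aminoalkyl group on the amide-type nitrogen.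

Compound 3 `O=C(CCC(=O)OCCCCCCSc1ccc([N+](=O)[O-])c2nonc12)NCCN1CCCC1` keeps the shared core and the whole chain of compound 2 and changes only the terminal amine: pyrrolidin-1-yl in place of dimethylamino on a saturated chain carbon, two bonds along the chain from an amide-type nitrogen. Going by the values given here, no measured step in this set bears directly on such a change; the one recorded step replaces the whole substituent on the amide-type nitrogen and says little about swapping one tertiary amine for another that keeps the same count of hydrogen-bond acceptors and no net charge. The step from compound 2 to compound 3 in this assay is therefore expected to stay within the scatter, as a 1.2-fold lower number from compound 2 to compound 3 (0.08 log units; within the scatter) indicates. For compound 3 the estimated value in this assay is 450 nM, with a range from 200 nM to 1200 nM.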

Compound 3, half-maximal inhibitory concentration: 460 nM
Beside the measured number, compound 3's estimate is 1.0-fold (0.01 log units) below it, and the stated range covers the measured number.
By their numbers in this assay, from the lowest: compounds 3 and 2 (each within the scatter of the next); then compound 1.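

In this assay, pyrrolidin-1-yl in place of dimethylamino on a saturated chain carbon, two bonds along the chain from an amide-type nitrogen, gives a 1.2-fold lower number from compound 2 to compound 3 (0.07 log units; within the scatter), so at this position the open dimethylamino group and the five-membered ring cannot be told apart on this read-out. The change from 4-bromophenyl to 2-(pyrrolidin-1-yl)ethyl on the amide-type nitrogen gives an 11-fold lower number from compound 1 to compound 3 (1.04 log units; beyond the scatter), which goes the same way as the earlier 9.4-fold lower number from compound 1 to compound 2 (0.97 log units; beyond the scatter), so the drop in the number now holds for two aminoalkyl groups rather than one. Nothing at hand accounts for either the match between the two amines or their gap to the 4-bromophenyl compound.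

Both amines shown are tertiary and sit on the same ethyl chain, so a morpholine, a piperidine, a primary amine or a longer chain to the amine remain open at this position. A plain alkyl group such as butyl or a carboxylic acid on the amide-type nitrogen would show whether the amine nitrogen itself goes with the lower numbers.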